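This account rests on a few compounds, and the source may have more. Where it says the series, first, only, none or still open, it means among the compounds named here.

Measured in a functional assay on MIA PaCa-2 cells (Homo sapiens) for cytotoxicity, read by MTT assay, with a stated time of 72 h, tested at 1 uM; on this read-out higher numbers stand for a weaker effect at the one concentration tested and lower numbers for a stronger effect:

- compound 1 `C=C1C(=O)O[C@H](c2ccc3ccccc3c2)[C@H]1C`: 74%
- compound 2 `C=C1C(=O)O[C@@H](c2ccccc2)[C@H]1c1ccccc1`: 32%
- compound 3 `C=C1C(=O)O[C@H](c2ccccc2)[C@H]1c1ccccc1`: 30%

Compound 3 gives the lowest of the three numbers. Its nearest neighbour is compound 2, and the step of a number 2 percentage points lower from compound 2 to compound 3 (within the scatter) rests on (the fact that compounds 2 and 3 differ only in the configuration as drawn); compound 1 lies further off, with a value beyond the scatter from that of compound 3.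

The next compound, compound 4 `C=C1C(=O)O[C@H](c2ccc(C)cc2)[C@H]1c1ccccc1`, differs from compound 3 in one place: methyl in place of hydrogen on an aromatic carbon. The change is small, a single carbon added to the six-membered aromatic ring of carbon only, at the place para to a large group.

Going by the values given here, none of the measured steps bears on this change. Among the compounds with values here, the only step measured within a single difference, from compound 2 to compound 3, concerns configuration at a saturated ring carbon and stays within the scatter; no compound here carries a methyl on an aromatic carbon, so the series gives no guide to the size or direction of such a step in this assay. Compound 4 is therefore expected to sit close to compound 3, with the step of no change at the digits printed from compound 3 to compound 4 (within the scatter) expected to fall within the scatter. Compound 4 is estimated at 30%, in the range 15% to 50%.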

Compound 4, a percentage reported as activity, at one concentration (the size of the read-out at that concentration, not a potency): 26%
Compound 4: the middle estimate sits 4 percentage points above what was measured; low and high end bracket the measured number.
By their numbers in this assay, from the lowest: compounds 4, 3 and 2 (each within the scatter of the next); then compound 1.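

In this assay, methyl in place of hydrogen on an aromatic carbon, para to a large group, gives a number 4 percentage points lower from compound 3 to compound 4 (within the scatter). Going by these compounds alone, this is the first single-place change on this six-membered aromatic ring of carbon only, and it shows that this place accepts the added methyl without the read-out leaving the scatter around compound 3, whereas the earlier step concerned only configuration at a saturated ring carbon. Nothing available on these compounds bears on why this step has the size it has.

A single methyl leaves open how far this place stays permissive: whether a longer chain such as propyl, or a methoxy, an amine or a carboxylic acid at the same carbon, would keep the read-out in the same range is not settled by the compounds shown. Also open, as far as these compounds go, are whether the methyl behaves alike on the configuration drawn in compound 2, and how compounds 3 and 4 compare in potency, since a reading at one concentration gives the size of the effect there and not a potency.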